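A few compounds are considered here, and "the series" means these few. Any claim that something is new, unique, unknown or untested is made for them only; others in the source may bear on it.

Compound 1 `O=C1CC(c2ccc(Cl)c(F)c2)Oc2cc(O)cc(O)c21`: 500000 nM
Compound 2 `O=C1CC(c2ccc(F)cc2)Oc2cc(O)cc(O)c21`: 1000000 nM

In a physicochemical assay for solubility (a higher number here means a more soluble compound, a lower number a less soluble compound), compound 2 reads 1000000 nM, which lies within the usual scatter of compound 1, so neither can be ranked above the other. Compound 3 `O=C1CC(c2ccc(F)c(F)c2)Oc2cc(O)cc(O)c21` is compound 2 with fluoro in place of hydrogen on an aromatic carbon. Among the measured compounds shown here, no measured pair shows this change alone. For the measured compounds named here, the only guide is compound 1, which also carries a fluoro group on that carbon and gives 500000 nM. The expected step is small, slightly downward and no larger than the scatter: a 1.4-fold lower number from compound 2 to compound 3 (0.15 log units; within the scatter). For compound 3 the estimated value is 700000 nM, with an expected range from 300000 nM to 1500000 nM.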

Compound 3, solubility: 1000000 nM
For compound 3 the middle estimate is 1.4-fold (0.15 log units) below the measured one; low and high end bracket the measured number.
By their numbers in this assay, from the lowest: compounds 1, 2 and 3 (each within the scatter of the next).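

Putting fluoro in place of hydrogen on an aromatic carbon, ortho to a fluoro group, gives no change at the digits printed from compound 2 to compound 3 (within the scatter) in this assay. Fluoro in place of chloro on another aromatic carbon gives a 2.0-fold higher number from compound 1 to compound 3 (0.30 log units; within the scatter), so neither swap can be told apart from repeat-measurement noise in this read-out. Nothing available explains these results.

From the compounds shown here alone, whether an amine, a carboxylic acid or a methoxy group on the first of these carbons would give a step beyond the scatter remains open.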